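Thiocarbonyl substituent swap: compound 2 to compound 3

This account rests on a few compounds, and the source may have more. Where it says the series, first, only, none or still open, it means among the compounds named here.

Measured so far in a functional assay on MCF7 cells (Homo sapiens) for antiproliferative activity, read by MTT assay, with a stated time of 96 h; a lower number here means a stronger inhibitor, a higher number a weaker inhibitor:
compound 1 `S=C(N/N=C1\CC2(CCCCC2)Oc2c1ccc1ccccc21)N1CCCCC1` gives 13400 nM
compound 2 `S=C(CN1CCCCC1)N/N=C1\CC2(CCCCC2)Oc2c1ccc1ccccc21` gives 11700 nM

Only these two values are available, and compound 2 stands level with compound 1 on them. Going by the values given here, the single measured step is a 1.1-fold lower number from compound 1 to compound 2 (0.06 log units; within the scatter), so the two cannot be told apart in this assay. Next in the series is compound 3 `S=C(N/N=C1\CC2(CCCCC2)Oc2c1ccc1ccccc21)NC1CCCCC1`, which carries cyclohexylamino in place of (piperidin-1-yl)methyl on a thiocarbonyl carbon.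

Among the compounds with values here, the one measured step changes the group on this same carbon, and that change from piperidin-1-yl to (piperidin-1-yl)methyl left the number within the scatter. Within the data shown here, it is weak evidence, since cyclohexylamino has no measured counterpart on this carbon. Still, nothing measured points to a direction, so no shift beyond the scatter is expected, and the range is kept wide. The expected step is a 1.2-fold lower number from compound 2 to compound 3 (0.07 log units; within the scatter) on this reasoning. For compound 3 the estimated value is 10000 nM, with 3500 nM to 25000 nM as the expected range.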

Compound 3, half-maximal inhibitory concentration: 15100 nM
Beside the measured number, compound 3's estimate is 1.5-fold (0.18 log units) below it; the range from low to high includes it.
By their numbers in this assay, from the lowest: compounds 2, 1 and 3 (each within the scatter of the next).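

In this assay, cyclohexylamino in place of (piperidin-1-yl)methyl on a thiocarbonyl carbon gives a 1.3-fold higher number from compound 2 to compound 3 (0.11 log units; within the scatter), and this swap keeps the heavy-atom count while exchanging a ring with a hetero atom for a carbon-only ring and a hydrogen-bond acceptor for a hydrogen-bond donor. Cyclohexylamino in place of piperidin-1-yl gives a 1.1-fold higher number from compound 1 to compound 3 (0.05 log units; within the scatter), so all three groups on this carbon, whether attached through a ring nitrogen, a methylene or an amino nitrogen, now stand level and cannot be told apart in this assay. Nothing on hand offers an explanation for this flat result.

As far as these compounds go, it remains open whether a group of a different kind on this thiocarbonyl carbon, such as an open-chain diethylamino group, an anilino group or a carboxylic acid on a longer chain, would move the number beyond the scatter. From the compounds shown here alone, all three compounds also share one core, so what a change to that core would do in this assay stays unknown.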